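The source may hold more compounds than are shown below. What is called first, only, known or untested is meant among the compounds shown, and "the series" means these compounds.

Notes on the series: a small set of esters and amides of a bicyclic alcohol or amine, each carrying a piperazine bearing either a methyl or an ethyl group, read in an ADME assay on HEK-293T cells (Homo sapiens) for cytotoxicity, read by MTT assay, with a stated time of 48 h; a lower number here means that less compound is tolerated, a higher number that more compound is tolerated.

Compound 1 `CN1CCN(CCC(=O)O[C@@H]2C[C@@H]3CC[C@@]2(C)C3(C)C)CC1` gives 282000 nM in this assay. Compound 2 `CCN1CCN(CCC(=O)O[C@@H]2C[C@@H]3CC[C@@]2(C)C3(C)C)CC1` gives 264000 nM in this assay. The two differ by methyl in place of hydrogen on a saturated chain carbon bound to an amine nitrogen in a ring, and the step is a 1.1-fold lower number from compound 1 to compound 2 (0.03 log units; within the scatter), so the pair shows no change that can be read as real.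

Compound 3 `CN1CCN(CC(=O)N[C@@H]2C[C@H]3CC[C@]2(C)C3(C)C)CC1` gives 853000 nM in this assay, the highest of the three numbers, with both compound 1 and compound 2 beyond the scatter below it. The difference between the core of compound 3 and the core of compound 1 is not broken down here.

Compound 4 `CCN1CCN(CC(=O)N[C@@H]2C[C@H]3CC[C@]2(C)C3(C)C)CC1` is not yet measured in this assay. It stands to compound 3 as compound 2 stands to compound 1: the difference is methyl in place of hydrogen on a saturated chain carbon bound to an amine nitrogen in a ring, the same change at the same place, seen twice across the four compounds.

For compound 4 the expectation in this assay is a step of a 1.1-fold lower number from compound 3 to compound 4 (0.03 log units; within the scatter), close to flat, because a 1.1-fold lower number from compound 1 to compound 2 (0.03 log units; within the scatter) stayed within the scatter when the same change was made on the ester pair. The estimate for compound 4 is therefore 800000 nM, with a range from 450000 nM to 1500000 nM that allows for the usual repeat scatter around the value of compound 3.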

Compound 4, half-maximal cytotoxic concentration: 660000 nM
Compound 4: the middle estimate sits 1.2-fold (0.08 log units) above what was measured, and the stated range covers the measured number.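

Working from the two pairs, methyl in place of hydrogen on a saturated chain carbon bound to an amine nitrogen in a ring gives in this assay a step of a 1.3-fold lower number from compound 3 to compound 4 (0.11 log units; within the scatter) on the core of compound 3, and this step stays as flat as the earlier one on the core of compound 1. Carried from one core to the other, the change shows no difference that can be read: the same change on two cores in this assay, a 1.1-fold lower number (0.03 log units; within the scatter) from compound 1 to compound 2 and a 1.3-fold lower number (0.11 log units; within the scatter) from compound 3 to compound 4, 1.2-fold (0.08 log units) apart, within the scatter of two such steps.

This holds only for methyl to ethyl, on these two cores and in this one cell read-out; two pairs with steps inside the scatter support a flat result here but give no rule for other cores, and they do not show that the change has no effect on any other property of the compounds.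

Still open, from the compounds shown here alone, is whether a larger group at the same place, such as a propyl chain, a benzyl group or a hydroxyethyl chain, would remain as flat as ethyl does here. Also open is what lies behind the higher number of compound 3 over compound 1, since the ester or amide link is not separated from the other differences between the two cores.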